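The compounds below may be only part of what the source reports. "The series", "measured", "known", "first", "only" and "open" are said of these compounds alone.

In a functional assay on DU-145 cells (Homo sapiens) for inhibition, read by trypan blue exclusion, with a stated time of 96 h (on this read-out higher numbers stand for weaker inhibition of growth and lower numbers for stronger inhibition of growth), compound 1 `O=C(/C(=C\c1ccc(Br)cc1)SCc1ccc(Cl)cc1)c1ccc(Br)cc1` gives 1000 nM as the lower of two numbers and compound 2 `O=C(/C(=C\c1c(O)cc(O)cc1O)S(=O)(=O)c1ccccc1Br)c1ccc(Br)cc1` gives 50000 nM as the higher. Compound 3 `O=C(/C(=C\c1ccc(O)cc1)SCc1ccc(Cl)cc1)c1ccc(Br)cc1` keeps the core of compound 1 but has hydroxy in place of bromo on an aromatic carbon, para to a large group, a change that reads as hydroxy in place of bromo on an aromatic carbon in full. Among the compounds with values here, no measured pair shows this change, so only a small rise in the number, meaning somewhat weaker inhibition of growth, is expected, perhaps within the scatter. The expected size is a 2.0-fold higher number from compound 1 to compound 3 (0.30 log units; within the scatter) in this estimate. For compound 3 the estimated value is 2000 nM with 400 nM to 10000 nM as the expected span.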

Compound 3, concentration for 50% growth inhibition: 10000 nM
Compound 3: the middle estimate sits 5.0-fold (0.70 log units) below what was measured; the measured number falls inside the stated range.
By their numbers in this assay, from the lowest: compound 1; then compound 3; then compound 2.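

In this assay, putting hydroxy in place of bromo on an aromatic carbon, para to a large group, gives a 10-fold higher number from compound 1 to compound 3 (1.00 log units; beyond the scatter) and so weaker inhibition of growth, a step beyond the scatter. This first single-change pair shows that growth inhibition responds to the group at this position while the rest of compound 1 stays the same. No measurement here explains the size of this step.
Going by these compounds, whether an amine, a methoxy group or a carboxylic acid at this position would keep or lose inhibition remains open. With one pair, no trend across groups can be drawn.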